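The source may report more compounds than this note shows. Statements on the series, on what has been measured and on what is new or still open speak of the compounds shown alone.

Measured compounds:
compound 1, `COC(=O)C1=C(C)NC(=O)NC1c1ccoc1`: 42%
compound 2, `CC(=O)C1=C(C)NC(=O)NC1c1ccoc1`: 15%

In an assay on membranes from HEK293 cells for displacement of a labelled ligand from adenosine receptor A2b (Homo sapiens), read by scintillation counting, with a stated time of 30 min, tested at 1 uM (on this read-out higher numbers stand for more inhibition at the one concentration tested (going by the name of the read-out) and lower numbers for less inhibition), compound 1 gives 42%, while compound 2 gives 15%. For the measured compounds named here, compound 2 therefore stands lowest of the two numbers, and the single measured step, a number 27 percentage points lower from compound 1 to compound 2 (beyond the scatter), is a modest fall that lies beyond the scatter. Compound 3, `CC1=C(C(N)=O)C(c2ccoc2)NC(=O)N1`, has not yet been measured. It differs from compound 2 by amino in place of methyl on a carbonyl carbon. Going by the values given here, the only step that bears on this position is a number 27 percentage points lower from compound 1 to compound 2 (beyond the scatter), since it also changes the group on the same carbonyl carbon; it was modest in size and downward. Among the compounds with values here, no step with an amino group entering is available, so the direction for compound 3 is open. The account expects no step beyond the scatter, a number 5 percentage points higher from compound 2 to compound 3 (within the scatter), from compound 2 to compound 3. Compound 3 is accordingly estimated at 20%, with a range from 0% to 45%.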

Compound 3, a percentage reported as inhibition, at one concentration (the size of the read-out at that concentration, not a potency): 6%
Compound 3: middle estimate off by 14 percentage points, on the high side, within the range that was stated.
By their numbers in this assay, from the lowest: compounds 3 and 2 (each within the scatter of the next); then compound 1.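

In this assay, amino in place of methyl on a carbonyl carbon gives a number 9 percentage points lower from compound 2 to compound 3 (within the scatter), so this change cannot be told apart from the scatter, whereas amino in place of methoxy gives a number 36 percentage points lower from compound 1 to compound 3 (beyond the scatter), a large step. Among the three groups now seen on this carbonyl carbon, only the methoxy of compound 1 stands apart from both others by more than the scatter, while methyl and amino read alike. No measurement at hand accounts for this difference.

The compounds shown leave open whether the higher number is particular to methoxy or would extend to a longer alkoxy group such as ethoxy. They also leave open how a methylamino group or a carboxylic acid on the same carbonyl carbon would read.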